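Sulfonylquinoxaline anilines: methoxy addition on the aniline ring

The compounds below may be only part of what the source reports. "The series", "measured", "known", "first", "only" and "open" are said of these compounds alone.

Three measured compounds share a core in which an aniline nitrogen and an arylsulfonyl group sit on the same quinoxaline. Compound 1 `COc1ccc(Nc2nc3ccccc3nc2S(=O)(=O)c2ccccc2)cc1` in a functional assay on A549 cells (Homo sapiens) for cytotoxicity, read by MTT assay, with a stated time of 72 h (on this read-out higher numbers stand for weaker inhibition and lower numbers for stronger inhibition), gives 11900 nM. Compound 2 `COc1ccc(Nc2nc3ccccc3nc2S(=O)(=O)c2ccc(OC)cc2)cc1` in this assay gives 8260 nM. Compound 3 `COc1cc(Nc2nc3ccccc3nc2S(=O)(=O)c2ccc(F)cc2)cc(OC)c1` in this assay gives 5450 nM; the gap between compound 3 and compound 1 lies beyond the scatter, while the gap to compound 2 does not.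

The change from compound 1 to compound 2 is methoxy in place of hydrogen on an aromatic carbon; its effect was a 1.4-fold lower number from compound 1 to compound 2 (0.16 log units; within the scatter). The difference between the cores of compound 1 and compound 3 is not broken down here.

Compound 4 `COc1cc(Nc2nc3ccccc3nc2S(=O)(=O)c2ccc(F)cc2)cc(OC)c1OC` is the unmeasured member. It differs from compound 3 by methoxy in place of hydrogen on an aromatic carbon. This is the same kind of change as that from compound 1 to compound 2, but not the same: in compound 4 the entering methoxy sits ortho to two methoxy groups (2 heavy atoms each) as well as para to a large group, whereas in compound 2 it sits only para to a large group.

Among the compounds with values here, on the one precedent, the step from compound 3 to compound 4 is expected to be about a 1.2-fold lower number from compound 3 to compound 4 (0.08 log units; within the scatter), resting on a 1.4-fold lower number from compound 1 to compound 2 (0.16 log units; within the scatter), which sat within the scatter. Compound 4 is therefore estimated at 4500 nM in this assay, with the range 2000 nM to 10000 nM allowing for the different surroundings of the new group.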

Compound 4, half-maximal inhibitory concentration: > 50000 nM
Compound 4: a limit, no number; the forecaster's own chance of this, stated with the estimate: 5%; middle value at least 11-fold (1.04 log units) away from the limit.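

In this assay, methoxy in place of hydrogen on an aromatic carbon gives an at least 9.1-fold higher number from compound 3 to compound 4 (0.96 log units; beyond the scatter), so the earlier step does not carry over to this core: the same change on two cores in this assay, a 1.4-fold lower number (0.16 log units; within the scatter) from compound 1 to compound 2 and an at least 9.1-fold higher number (0.96 log units; beyond the scatter) from compound 3 to compound 4, at least 13-fold (1.12 log units) apart, beyond the scatter of two such steps. The value of compound 4, > 50000 nM, is a limit and not a number, so this step has a lower bound only: the limit of > 50000 nM in this assay, at which 1 of the 4 values shown sits. What the two steps do not show is why they part, since the entering methoxy sits ortho to two methoxy groups as well as para to a large group in compound 4 but only para to a large group in compound 2, the cores of compound 1 and compound 3 differ as well, and one pair on each core cannot separate these differences.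

Open, going by these compounds, is whether the result in this assay belongs to methoxy itself or to any group at that place, a question that a hydroxy group, a fluorine atom or an ethoxy group on the same carbon of the core of compound 3 would address. Also open, on these data alone, is whether the step would remain as large with a hydrogen or a methoxy group in place of the fluorine of compound 3.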